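Methyl in Place of Methoxy in a Cytotoxicity Series

A few compounds are considered here, and "the series" means these few. Any claim that something is new, unique, unknown or untested is made for them only; others in the source may bear on it.

Measured in a functional assay on B16-F10 cells (Mus musculus) for cytotoxicity, read by MTT assay, with a stated time of 72 h; on this read-out lower numbers stand for stronger inhibition and higher numbers for weaker inhibition:
- compound 1 `COc1ccc2[nH]c(-c3ccc[nH]3)c(C3CC(=O)NC3=O)c2c1`: 600 nM
- compound 2 `c1ccc2[nH]c(-n3cccn3)cc2c1`: > 100000 nM
- compound 3 `COc1ccc2[nH]c3c(c4c(c5ccnn53)C(=O)NC4=O)c2c1`: "not determined" (no result reported)

Not yet measured: compound 4 `Cc1ccc2[nH]c3c(c4c(c5ccnn53)C(=O)NC4=O)c2c1`

For the measured compounds named here, only one of these entries is a plain number, the one for compound 1. Compound 2 gives only a limit of the assay, > 100000 nM.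

Compound 3 has no number at all: its entry in this assay reads "not determined" (no result reported). Going by the values given here, it therefore offers no firm starting point for the next comparison, and no measured step shows how far a single change moves the result.

The change in question is methyl in place of methoxy on an aromatic carbon. In words, methyl takes the place of methoxy on an aromatic carbon of a six-membered aromatic ring of carbon only, and the rest of the structure stays the same. For this swap, no step beyond the usual scatter is expected in this assay, and neither direction is favoured. With compound 1 at 600 nM as the only numerical anchor, the expectation remains loose.

Compound 4 is expected to read about 5000 nM, with an estimated range of 400 nM to 60000 nM.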

Compound 4, half-maximal inhibitory concentration: 37000 nM
Beside the measured number, compound 4's estimate is 7.4-fold (0.87 log units) below it, within the range that was stated.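

In this assay, for the compounds shown here, compound 4 gives 37000 nM while compound 3 has no reported number, so no step between compound 3 and compound 4 can be read. The compounds shown leave open how far methyl in place of methoxy moves the result on this shared core. Nothing shown bears on the reading of compound 4.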